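A few compounds are considered here, and "the series" means these few. Any claim that something is new, unique, unknown or untested is made for them only; others in the source may bear on it.

Measured so far in a functional assay on MDA-MB-231 cells (Homo sapiens) for inhibition, read by MTT assay, with a stated time of 48 h; a higher number here means a weaker inhibitor, a lower number a stronger inhibitor:
compound 1 `COc1cc(-c2cc(/C=C/C(=O)c3ccc(N)cc3)[nH]n2)cc(OC)c1OC` gives 2000 nM
compound 2 `COc1cc(-c2cc(/C=C/C(=O)c3ccc(Cl)c(Cl)c3)[nH]n2)cc(OC)c1OC` gives 2100 nM
compound 3 `COc1cc(-c2cc(/C=C/C(=O)c3ccc(Cl)cc3)[nH]n2)cc(OC)c1OC` gives 26000 nM

Compound 3 stands at the highest of the three numbers. Its nearest neighbour is compound 2, and the step of a 12-fold higher number from compound 2 to compound 3 (1.09 log units; beyond the scatter) lies beyond the scatter, as does a 13-fold higher number from compound 1 to compound 3 (1.11 log units; beyond the scatter). By contrast a 1.1-fold higher number from compound 1 to compound 2 (0.02 log units; within the scatter) lies within the scatter.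

Compound 4 `COc1cc(-c2cc(/C=C/C(=O)c3ccccc3)[nH]n2)cc(OC)c1OC` has not yet been measured. It differs from compound 3 in one place: hydrogen in place of chloro on an aromatic carbon.

The measured step of the same kind is a 12-fold higher number from compound 2 to compound 3 (1.09 log units; beyond the scatter), where a chloro gave way to hydrogen on the same ring and the number rose strongly. The step of a 13-fold higher number from compound 1 to compound 3 (1.11 log units; beyond the scatter) shows that an exchange on the aromatic carbon that is now concerned also moved the number strongly. Neither pair repeats the present exchange exactly, so the guidance is loose. A further rise in the number is expected, but a smaller one, since compound 3 already gives 26000 nM. The expected step is a 1.5-fold higher number from compound 3 to compound 4 (0.19 log units; within the scatter). Compound 4 is therefore estimated at 40000 nM, with a range from 12000 nM to 130000 nM.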

Compound 4, half-maximal inhibitory concentration: 2300 nM
For compound 4 the middle estimate is 17-fold (1.24 log units) above the measured one, outside the stated range (below it).
By their numbers in this assay, from the lowest: compounds 1, 2 and 4 (each within the scatter of the next); then compound 3.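

In this assay, the loss of chloro from the 4-chlorophenyl group does not raise the number further, and an 11-fold lower number from compound 3 to compound 4 (1.05 log units; beyond the scatter) is a large step in the opposite direction, so the 4-chlorophenyl to phenyl change does not extend the rise seen on going to compound 3. Within the data shown here, the phenyl compound instead falls in with the other two, with a 1.1-fold higher number from compound 2 to compound 4 (0.04 log units; within the scatter) and a 1.2-fold higher number from compound 1 to compound 4 (0.06 log units; within the scatter) both within the scatter, so hydrogen, amino and the 3,4-dichlorophenyl pattern are not told apart here, and compound 3 is the single compound out of line among the four. Nothing at hand gives a reason for this isolated behaviour of the 4-chlorophenyl compound.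

Open, from the compounds shown here alone, is whether the weak result is particular to chloro or recurs with other single groups on the same aromatic carbon, such as fluoro, bromo, methoxy or a nitrile. Also open, going by these compounds, is whether a carboxylic acid or a dimethylamino group there would stay with compound 1, compound 2 and compound 4 or move away from them.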